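Removing the acetyl from compound 2

The source may report more compounds than this note shows. Statements on the series, on what has been measured and on what is new or still open speak of the compounds shown alone.

Compound 1 `COc1ccc(NC(=O)c2c(NC(=O)c3ccccc3)sc3c2CCCCC3)cc1` and compound 2 `CC(=O)Nc1sc2c(c1C(=O)OC(C)(C)C)CCCCC2` share a core and are both reported in an ADME assay on THP-1 cells (Homo sapiens) for cytotoxicity; on this read-out higher numbers stand for lower toxicity in this test and lower numbers for higher toxicity in this test. In this assay compound 1 gives > 50000 nM, which is a limit of the assay rather than a number. In this assay compound 2 gives > 50000 nM, again a limit. Compound 2 thus stands at the limit of > 50000 nM in this assay, at which 2 of the 2 values shown sit. Compound 3 `CC(C)(C)OC(=O)c1c(N)sc2c1CCCCC2` differs from compound 2 by hydrogen in place of acetyl on a nitrogen on an aromatic ring. For the measured compounds named here, no measured step exists for this change, so the step of a number no higher from compound 2 to compound 3 (the limit leaves the size open) is expected to remain within the scatter. Compound 3 is estimated at 50000 nM, in the range 20000 nM to 100000 nM, most likely again as a limit.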

Compound 3, half-maximal cytotoxic concentration: > 50000 nM
Compound 3 gave a limit, no number (the forecaster's own chance of this, stated with the estimate: 75%); the middle value sits exactly at the limit.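

For the compounds shown here, no step from compound 2 to compound 3 can be read in this assay, as both values are limits rather than numbers. The compounds shown leave open whether going from acetamido to amino changes this read-out at all.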